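Sec-Butyl Replaces Phenyl: From Compound 2 to Compound 3

The compounds below may be only part of what the source reports. "The series", "measured", "known", "first", "only" and "open" are said of these compounds alone.

Compound 1, `CC(C)C(NC(=O)NO)C(=O)NC1CCCC1`: > 100000 nM
Compound 2, `O=C1NC(c2ccccc2)C(=O)N1C1CCCC1`: > 100000 nM

Both values shown in a functional assay on SW-620 cells (Homo sapiens) for inhibition (on this read-out higher numbers stand for weaker inhibition and lower numbers for stronger inhibition), are limits of the assay rather than numbers. Compound 1 reaches only the limit > 100000 nM. Compound 2 likewise gives the limit > 100000 nM. Compound 2 therefore stands at the limit, the position of every value shown (the limit of > 100000 nM in this assay, at which 2 of the 2 values shown sit). Compound 3 `CCC(C)C1NC(=O)N(C2CCCC2)C1=O` differs from compound 2 by sec-butyl in place of phenyl on a saturated ring carbon. No measured step connects any of these compounds. Compound 3 is expected to remain near the same limit, with an estimated step that the limit leaves unreadable from compound 2 to compound 3 no larger than the scatter. Compound 3 is estimated at 150000 nM, ranging from 30000 nM to 1000000 nM.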

Compound 3, half-maximal inhibitory concentration: > 100000 nM
Compound 3 ended at the assay's limit (the forecaster's own chance of this, stated with the estimate: 85%); the middle value does not contradict the limit.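

Among the compounds shown here, compound 2 and compound 3 both give only limits in this assay, so no step between them can be read. The compounds shown leave open how strongly any of them inhibits, and how sec-butyl and phenyl compare at this place.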